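Series notes: aminopyrimidine in place of the benzamide

The source may report more compounds than this note shows. Statements on the series, on what has been measured and on what is new or still open speak of the compounds shown alone.

Measured compounds:
- compound 1, `CC(=O)c1cc(C(=O)N[C@@H](C)Cn2ccc(-c3cc(F)c(C#N)c(Cl)c3)n2)n[nH]1`: "not determined" (no result reported)
- compound 2, `C[C@@H](Cn1ccc(-c2ccc(C#N)c(Cl)c2)n1)NC(=O)c1ccccc1F`: 2190 nM
- compound 3, `CC(Cn1ccc(-c2ccc(C#N)c(Cl)c2)n1)C(=O)Nc1cccc(C(C)O)c1`: > 30000 nM

In a functional assay on VCaP cells (Homo sapiens) for antiproliferative activity, read by CCK-8 assay, with a stated time of 6 days (on this read-out higher numbers stand for weaker inhibition and lower numbers for stronger inhibition), compound 2 gives 2190 nM, the only numeric result among the three compounds shown. Compound 3 sits at a limit of this assay, reported as > 30000 nM, so it carries no number; this is the limit of > 30000 nM in this assay, at which 1 of the 3 values shown sits, and it cannot be set against compound 2 in size. Compound 1 has no result in this assay at all. Compound 2 therefore stands alone as the single measured reference point for the series.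

The next compound, compound 4, `Cc1ccnc(N[C@@H](C)Cn2ccc(-c3ccc(C#N)c(Cl)c3)n2)n1`, differs from compound 2 in one place: 4-methylpyrimidin-2-yl in place of (2-fluorophenyl)carbonyl on an amine nitrogen. Within the data shown here, no pair of measured compounds differing in one place exists here, so the effect of exchanging a carbonyl-linked group for a heteroaromatic ring on this amine nitrogen is untested. With only compound 2 as an anchor, the expectation is a modest step in this assay, a 1.5-fold lower number from compound 2 to compound 4 (0.16 log units; within the scatter), whose direction is uncertain and may not exceed the usual scatter. Compound 4 is accordingly estimated at 1500 nM, with a plausible range from 300 nM to 8000 nM in this assay.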

Compound 4, half-maximal inhibitory concentration: 850 nM
Estimate against measurement, compound 4: 1.8-fold (0.25 log units) above, within the range that was stated.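

At the amine nitrogen whose other neighbour is a saturated chain carbon, the series now has its first readable step in this assay: a 2.6-fold lower number from compound 2 to compound 4 (0.41 log units; beyond the scatter). The (2-fluorophenyl)carbonyl group is therefore not needed for activity in this assay, since an aromatic ring with hetero atoms attached directly to the same nitrogen, 4-methylpyrimidin-2-yl, gives a lower number, and this exchange removes the carbonyl as well as changing the ring. No measured property in hand bears on why the number moved at this position.

This single pair cannot separate the contribution of the methyl group from that of the pyrimidine ring, or the loss of the carbonyl from the change of ring, so the unsubstituted pyrimidin-2-yl and a pyridin-2-yl group on the same nitrogen would be the informative comparisons. Going by these compounds, it also remains open whether the lower number extends to other groups at this nitrogen, such as a 4-methoxypyrimidin-2-yl or 4-trifluoromethylpyrimidin-2-yl ring, or persists on a longer chain in place of the saturated chain carbon.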